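The compounds below may be only part of what the source reports. "The series", "measured", "known", "first", "only" and "open" are said of these compounds alone.

Measured compounds in this set:
compound 1, `COc1cccc(N2C(=O)COc3ccc(-c4cnc(OC)c(NS(=O)(=O)c5ccc(F)cc5)c4)cc32)c1`: 11200 nM
compound 2, `COc1ncc(-c2ccc3c(c2)N(C2CCCCC2)C(=O)CO3)cc1NS(=O)(=O)c1ccc(F)cc1`: 24600 nM
compound 3, `COc1cccc(N2C(=O)COc3ccc(-c4cnc5ccccc5c4)cc32)c1`: a limit only, > 40000 nM

In a functional assay on A549 cells (Homo sapiens) for antiproliferative activity, read by MTT assay, with a stated time of 72 h (on this read-out higher numbers stand for weaker inhibition and lower numbers for stronger inhibition), compound 1 gives 11200 nM and compound 2 gives 24600 nM. The change between them is cyclohexyl in place of 3-methoxyphenyl on an amide-type nitrogen in a ring, and it produced a 2.2-fold higher number from compound 1 to compound 2 (0.34 log units; beyond the scatter). For compound 3 this assay reports only a limit, > 40000 nM. How the core of compound 3 differs from the core of compound 1 is not broken down here. Compound 4, `O=C1COc2ccc(-c3cnc4ccccc4c3)cc2N1C1CCCCC1`, carries the same change as compound 2, namely (cyclohexyl in place of 3-methoxyphenyl on an amide-type nitrogen in a ring). Because compound 3 already sits at the limit of > 40000 nM in this assay, at which 1 of the 3 values shown sits, and because that change gave a 2.2-fold higher number from compound 1 to compound 2 (0.34 log units; beyond the scatter), compound 4 is expected to stay at or beyond that limit rather than improve. Compound 4 is expected to move by a step that the limit leaves unreadable from compound 3 to compound 4. Compound 4 is therefore estimated at 70000 nM, within 30000 nM to 200000 nM.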

Compound 4, half-maximal inhibitory concentration: > 40000 nM
Compound 4: no number, only a limit; the forecaster's own chance of this, stated with the estimate: 85%; the middle value is on the limit's open side.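

Among these compounds, compound 3 and compound 4 are both reported only as limits, so no step between them can be read: the limit of > 40000 nM in this assay, at which 2 of the 4 values shown sit. The compounds shown leave open how cyclohexyl in place of 3-methoxyphenyl acts on the core of compound 3.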